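The source may hold more compounds than are shown below. What is called first, only, known or untested is meant among the compounds shown, and "the series" means these compounds.

In a functional assay on KBVIN cells (Homo sapiens) for antiproliferative activity, read by sulforhodamine B assay, with a stated time of 3 days (a lower number here means that less compound is needed, a higher number that more compound is needed for the effect), compound 1 `CCC1=C(O)c2c(oc(-c3ccc(C(C)C)cc3)cc2=O)C(CC)(CC)C1=O` gives 1.08 uM and compound 2 `CCC1=C(O)c2c(oc(-c3ccc(Br)cc3)cc2=O)C(CC)(CC)C1=O` gives 15.7 uM, while compound 3 `CCC1=C(O)c2c(oc(-c3cc(C)c(C)cc3C)cc2=O)C(CC)(CC)C1=O` gives 4.37 uM as the second highest of the three numbers. Compound 4 `CCC1=C(O)c2c(oc(-c3ccc(O)c(O)c3)cc2=O)C(CC)(CC)C1=O` carries 3,4-dihydroxyphenyl in place of 2,4,5-trimethylphenyl on an aromatic carbon next to the ring oxygen (3,4-dihydroxyphenyl in place of 2,4,5-trimethylphenyl on an aromatic carbon). Three measured steps change this same aryl group, one large (a 15-fold higher number from compound 1 to compound 2 (1.16 log units; beyond the scatter)) and two modest (a 4.0-fold higher number from compound 1 to compound 3 (0.61 log units; beyond the scatter) and a 3.6-fold lower number from compound 2 to compound 3 (0.56 log units; beyond the scatter)). Among the compounds with values here, no measured compound holds a hydroxy group on this ring, so the direction is uncertain, but a modest rise in this assay is expected. The estimated step (a 2.3-fold higher number from compound 3 to compound 4 (0.36 log units; beyond the scatter)) is of that modest size. Compound 4 is expected at 10 uM with an estimated range from 3 uM to 30 uM in this read-out.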

Compound 4, concentration for half-maximal effect: 5.41 uM
Beside the measured number, compound 4's estimate is 1.8-fold (0.27 log units) above it; the measured number falls inside the stated range.
By their numbers in this assay, from the lowest: compound 1; then compounds 3 and 4 (each within the scatter of the next); then compound 2.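

In this assay, within the data shown here, putting 3,4-dihydroxyphenyl at this position, the first aryl group here with hydroxy groups, leaves the number level with that of the 2,4,5-trimethylphenyl group (a 1.2-fold higher number from compound 3 to compound 4 (0.09 log units; within the scatter)). The dihydroxy ring still gives a lower number than 4-bromophenyl (a 2.9-fold lower number from compound 2 to compound 4 (0.46 log units; beyond the scatter)) and a higher one than 4-isopropylphenyl (a 5.0-fold higher number from compound 1 to compound 4 (0.70 log units; beyond the scatter)), so this position accepts hydroxy groups without leaving the range already seen. Nothing at hand accounts for these steps.

As far as these compounds go, whether a single hydroxy group would behave like the pair remains open. So does the effect of an amine or a carboxylic acid on this aryl ring.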